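The source may hold more compounds than are shown below. What is called first, only, known or untested is meant among the compounds shown, and "the series" means these compounds.

Compound 1, `Cc1nccn1-c1cnc(NCc2c(F)ccc3c2CCO3)c2cn[nH]c(=O)c12`, and compound 2, `Cc1ncccc1-c1cnc(NCc2c(F)ccc3c2CCO3)c2n[nH]c(=O)n12`, share one core and have both been tested in an ADME assay on microsomes from liver (Homo sapiens) for metabolic stability, read by LC-MS, using NADPH, with stated times of 5 min and 30 min, tested at 1 uM; on this read-out lower numbers stand for slow clearance and higher numbers for fast clearance. In this assay compound 1 gives 8 mL.min-1.g-1, and compound 2 gives 8 mL.min-1.g-1, so compound 1 stands level with compound 2 within the usual scatter; neither can be called the slower of the two.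

Compound 3, `CNC(=O)c1ncc(-c2cnc(NCc3c(F)ccc4c3CCO4)c3cn[nH]c(=O)c23)n1C`, has not yet been measured. It differs from compound 1 in one place: 1-methyl-2-(methylcarbamoyl)-1H-imidazol-5-yl in place of 2-methyl-1H-imidazol-1-yl on an aromatic carbon. Within the data shown here, no pair of measured compounds shows this kind of change, so the size of the step cannot be read from the data; the two measured values only show that the core itself sits at low clearance in this assay.

The expectation for compound 3 is therefore a step of about a 1.1-fold lower number from compound 1 to compound 3 (0.06 log units; within the scatter), no larger than the scatter, in either direction. Compound 3 is estimated at 7 mL.min-1.g-1, with a range from 3 mL.min-1.g-1 to 15 mL.min-1.g-1.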

Compound 3, intrinsic clearance in microsomes: 24 mL.min-1.g-1
Compound 3: middle estimate off by 3.4-fold (0.54 log units), on the low side; measured number outside the range, above it.
By their numbers in this assay, from the lowest: compounds 1 and 2 (each within the scatter of the next); then compound 3.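

In this assay, the result shows that this aromatic carbon is not indifferent to the group placed on it: 1-methyl-2-(methylcarbamoyl)-1H-imidazol-5-yl in place of 2-methyl-1H-imidazol-1-yl gives a 3.0-fold higher number from compound 1 to compound 3 (0.48 log units; beyond the scatter). Low clearance is therefore not a fixed feature of the shared core, although this conclusion rests on a single pair. No measurement at hand shows what within this change produces the rise.

The change combines two differences, the added methylcarbamoyl group and the imidazole's attachment through a different ring atom, and this one pair cannot separate them. A comparison with 1-methyl-1H-imidazol-5-yl, which has no amide, or with a carboxylic acid in place of the methylcarbamoyl group, would show how much of the step follows the amide.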